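Swapping the halogenated phenyl ring on a diaminotriazine core

This account rests on a few compounds, and the source may have more. Where it says the series, first, only, none or still open, it means among the compounds named here.

The compounds here share a core of two amino groups on a triazine ring that is fused, through a spiro carbon, to a saturated six-membered ring, and carry a three-carbon chain ending in a phenoxy group. Compound 1 `NC1=NC2(CCSCC2)N(OCCCOc2cccc(Cl)c2)C(N)=N1` has a sulfur in its saturated ring and a 3-chlorophenoxy end; in an assay on isolated protein for inhibition of Dihydrofolate reductase (Homo sapiens), read by spectrophotometry, using NADPH, with stated times of 5 s and 6 min, tested at 50 uM (a higher number here means a stronger effect of the compound at the concentration tested, a lower number a weaker effect), compound 1 gives 88.8%. Compound 2 `NC1=NC2(CCOCC2)N(OCCCOc2ccc(F)cc2)C(N)=N1` replaces the sulfur with oxygen and carries a 4-fluorophenoxy end; in this assay compound 2 gives "not determined" (no result reported), so there is no number for it, and compound 1 is the only measured point of reference.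

Compound 3 `NC1=NC2(CCOCC2)N(OCCCOc2ccccc2Br)C(N)=N1` keeps the oxygen-containing ring of compound 2 and differs from it only at the far end of the chain: 2-bromophenyl in place of 4-fluorophenyl on an oxygen on a saturated carbon. The 4-fluorophenyl leaves and a 2-bromophenyl enters. Within the data shown here, with no measured pair to calibrate the size of this step, nothing can be said about its direction beyond the scatter. Given that compound 1, the closest measured relative, gives 88.8%, compound 3 is expected to inhibit to about 80%, with a range from 55% to 97%.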

Compound 3, a percentage reported as inhibition, at one concentration (the size of the read-out at that concentration, not a potency): 85%
Compound 3: the middle estimate sits 5 percentage points below what was measured; the measured number falls inside the stated range.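

No step can be read from compound 3: compound 2 has no number in this assay to set against it, and compound 1 differs from compound 3 in more than one place. The compounds shown leave open how 4-fluorophenoxy to 2-bromophenoxy, taken alone, changes inhibition. Nothing shown offers an explanation for the result.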